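This account rests on a few compounds, and the source may have more. Where it says the series, first, only, none or still open, it means among the compounds named here.

Going by the values given here, compound 1, `COc1ccc2c(=O)c(/C=C/C(=O)Nc3ccccc3Cl)coc2c1`, is the only member of this small set with a number in a functional assay on Huh-7 cells (Homo sapiens) for inhibition, read by MTT assay, with a stated time of 48 h; a lower number here means a stronger inhibitor, a higher number a weaker inhibitor: compound 1 gives 58400 nM. Compound 2, `COc1ccc(NC(=O)/C=C/c2coc3cc(OC)ccc3c2=O)cc1`, reaches only a limit of the assay in this assay, where compound 2 gives > 100000 nM. Compound 3, `Cc1ccc(CNC(=O)/C=C/c2coc3cc(O)ccc3c2=O)cc1`, likewise sits at a limit, and in this assay compound 3 gives > 100000 nM. Among the compounds with values here, the one step with both ends measured is an at least 1.7-fold higher number from compound 1 to compound 2 (0.23 log units; that floor lies within the scatter), a step whose floor lies within the scatter, so it shows no more than that compound 2 is not stronger than compound 1. The account now turns to compound 4, `COc1ccc2c(=O)c(/C=C/C(=O)Nc3ccc(Cl)cc3)coc2c1`, which differs from compound 1 as follows: 4-chlorophenyl in place of 2-chlorophenyl on an amide-type nitrogen. Within the data shown here, no measured step compares a 2-chlorophenyl with a 4-chlorophenyl, so the step from compound 1 to compound 2 is the nearest guide, and it bears only loosely on this change. Two of the three values shown sit at the limit of > 100000 nM in this assay, at which 2 of the 3 values shown sit, which makes a limit for compound 4 a real possibility. The step expected is a 1.2-fold higher number from compound 1 to compound 4 (0.08 log units; within the scatter), with no clear direction beyond the scatter. Compound 4 is therefore estimated at 70000 nM, within a range of 25000 nM to 200000 nM.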

Compound 4, half-maximal inhibitory concentration: 37100 nM
Beside the measured number, compound 4's estimate is 1.9-fold (0.28 log units) above it, within the range that was stated.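

The move of the chlorine from 2-chlorophenyl to 4-chlorophenyl on the amide-type nitrogen gives a 1.6-fold lower number from compound 1 to compound 4 (0.20 log units; within the scatter), so this assay does not separate these two arrangements of the same atoms. Going by these compounds alone, the change of chloro in place of methoxy on an aromatic carbon gives an at least 2.6-fold lower number from compound 2 to compound 4 (0.43 log units; beyond the scatter), which is the first step in the set to pass the scatter, and it favours the chloro group at this place on the ring. Even so, that step is only a floor on the true difference, because compound 2 has a limit of the assay rather than a number: the limit of > 100000 nM in this assay, at which 2 of the 4 values shown sit.

The compounds shown leave open how a fluoro group, a trifluoromethyl group or an amine would fare in place of the chloro group on this ring, and whether any such group would move the number beyond the scatter. Within the data shown here, compound 3 differs from the other compounds in more than one place, so no step to it can be read, and what a hydroxy group in place of the methoxy group on the shared core does on its own also stays open.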